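Replacing Nitro with Amino on Two Related Cores

The source may report more compounds than this note shows. Statements on the series, on what has been measured and on what is new or still open speak of the compounds shown alone.

Compound 1 `COc1cc(OC)n2cc(-c3ccc([N+](=O)[O-])cc3)nc2n1` and compound 2 `COc1cc(OC)n2cc(-c3ccc(N)cc3)nc2n1` share one core, while compound 3 `Cc1ccn2cc(-c3ccc([N+](=O)[O-])cc3)nc2c1` and compound 4 `Cc1ccn2cc(-c3ccc(N)cc3)nc2c1` share another; the difference between the two cores is not broken down here. In a functional assay on HT-29 cells (Homo sapiens) for antiproliferative activity, read by MTT assay, with a stated time of 72 h (a higher number here means a weaker inhibitor of growth, a lower number a stronger inhibitor of growth), compound 1 gives only a limit, > 100000 nM. Compound 2 likewise gives only a limit in this assay, > 100000 nM. The change amino in place of nitro on an aromatic carbon therefore leaves a step that the two limits leave unreadable from compound 1 to compound 2. Compound 3 also gives only a limit in this assay, > 100000 nM. The change from compound 3 to compound 4 is the same, (amino in place of nitro on an aromatic carbon), made on the other core. For the measured compounds named here, because the limit of > 100000 nM in this assay, at which 3 of the 3 values shown sit, every value so far sits at that limit, compound 4 is expected to remain there as well, a step that the limit leaves unreadable from compound 3 to compound 4. Compound 4 is accordingly estimated at 200000 nM, between 100000 nM and 1000000 nM.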

Compound 4, concentration for 50% growth inhibition: 93600 nM
Compound 4: the middle estimate sits 2.1-fold (0.33 log units) above what was measured, outside the stated range (below it).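

In this assay, amino in place of nitro on the core of compound 3 gives an at least 1.0-fold lower number from compound 3 to compound 4 (0.02 log units; that floor lies within the scatter). On these data alone, compound 4 alone carries a measured number, so this step has only a floor and its true size stays open: the limit of > 100000 nM in this assay, at which 3 of the 4 values shown sit. The same change on the core of compound 1 gives a step that cannot be read, so the data show neither agreement nor disagreement between the two cores, and nothing about carrying the change across is settled.

The compounds shown leave open whether an acetamide or a dimethylamino group in place of nitro would give a readable number on either core. They also leave open how the amino compounds on these cores would compare with a hydroxyl group there.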